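A few compounds are considered here, and "the series" means these few. Any claim that something is new, unique, unknown or untested is made for them only; others in the source may bear on it.

Measured in an ADME assay on cells (Hepatocyte, Mus musculus) for cytotoxicity, read by MTT assay, with a stated time of 24 h; a higher number here means that more compound is tolerated, a lower number that less compound is tolerated:
- Compound 1 `O=S(=O)(c1ccc(Cl)cc1)n1c(-c2cn(-c3ccccc3)nc2-c2ccc(F)cc2)nc2ccccc21`: 231000 nM
- Compound 2 `O=S(=O)(c1ccc(Br)cc1)n1c(-c2cn(-c3ccccc3)nc2-c2ccc(F)cc2)nc2ccccc21`: > 300000 nM (a limit of the assay, not a number)
- Compound 3 `O=S(=O)(c1ccc(C(F)(F)F)cc1)n1c(-c2cn(-c3ccccc3)nc2-c2ccc(F)cc2)nc2ccccc21`: 55300 nM

Compound 3 stands lowest of the three, at 55300 nM. Its nearest neighbour is compound 1, and the gap between them is a 4.2-fold lower number from compound 1 to compound 3 (0.62 log units; beyond the scatter).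

The next structure is compound 4 `O=S(=O)(c1ccc(C(F)(F)F)cc1)n1c(-c2cn(-c3ccccc3)nc2-c2ccc(C(F)(F)F)cc2)nc2ccccc21`. Its difference is trifluoromethyl in place of fluoro on an aromatic carbon, which means trifluoromethyl in place of fluoro on an aromatic carbon, para to a large group. The same difference reads 4-fluorophenyl to 4-(trifluoromethyl)phenyl.

Among the measured compounds shown here, two measured steps bear on this change, since both bring in trifluoromethyl on an aromatic carbon. The first is a 4.2-fold lower number from compound 1 to compound 3 (0.62 log units; beyond the scatter), and the second is an at least 5.4-fold lower number from compound 2 to compound 3 (0.73 log units; beyond the scatter). Neither replaces fluoro, and neither touches the 4-fluorophenyl group, so they serve only as a rough guide. The step of an at least 1.2-fold higher number from compound 1 to compound 2 (0.11 log units; that floor lies within the scatter) does not involve trifluoromethyl and offers no guidance here.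

On that basis, a modest move in the same direction is expected in this assay. The expected step is a 2.8-fold lower number from compound 3 to compound 4 (0.44 log units; beyond the scatter). For compound 4 the estimated value is 20000 nM, with an expected range from 6000 nM to 70000 nM.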

Compound 4, half-maximal cytotoxic concentration: 137000 nM
Beside the measured number, compound 4's estimate is 6.9-fold (0.84 log units) below it, and the stated range ends below it.
By their numbers in this assay, from the lowest: compound 3; then compounds 4 and 1 (each within the scatter of the next). At a limit, above all of these: compound 2.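

In this assay, the change from 4-fluorophenyl to 4-(trifluoromethyl)phenyl gives a 2.5-fold higher number from compound 3 to compound 4 (0.39 log units; beyond the scatter), so at this place trifluoromethyl goes with more compound being tolerated. The earlier compounds shown here showed the same group entering at another place, in place of chloro with a 4.2-fold lower number from compound 1 to compound 3 (0.62 log units; beyond the scatter) and in place of bromo with an at least 5.4-fold lower number from compound 2 to compound 3 (0.73 log units; beyond the scatter), both in the opposite direction. Among these compounds, then, bringing in trifluoromethyl has no single direction: the outcome differs between the two places and the groups it replaces, and nothing given here accounts for that difference.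

The compounds shown leave open whether the change from 4-fluorophenyl to 4-(trifluoromethyl)phenyl would go the same way on the core of compound 1 or compound 2, which carry chloro and bromo where compound 3 carries trifluoromethyl. They also leave open how this place would respond to a group of another kind, such as an amine, a carboxylic acid or a methoxy group, since only fluoro and trifluoromethyl appear there so far.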